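A few compounds are considered here, and "the series" means these few. Any claim that something is new, unique, unknown or untested is made for them only; others in the source may bear on it.

The measured compounds:
compound 1, `CC(=O)c1ccc(Nc2ccnc(SCC(=O)c3ccc(Br)cc3)n2)cc1`, giving 18% in a functional assay on MCF7 cells (Homo sapiens) for inhibition, read by sulforhodamine B assay, with a stated time of 48 h, tested at 10 uM; a lower number here means less inhibition of growth, a higher number more inhibition of growth at the concentration tested;
compound 2, `CCOC(=O)c1ccc(Nc2ccnc(SCC(=O)c3ccc([N+](=O)[O-])cc3)n2)cc1`, giving 22% in this assay.

The two values lie within the scatter of each other, so neither compound can be set above the other in this assay. Compound 3, `CCOC(=O)c1ccc(Nc2ccnc(SCC(=O)c3ccc(C#N)cc3)n2)cc1`, differs from compound 2 by one change: cyano in place of nitro on an aromatic carbon. Within the data shown here, no measured pair shows this change, so its size is unknown; nothing among the measured compounds suggests a move beyond the scatter in either direction. The estimate for compound 3 in this assay is therefore 20%, between 8% and 35%, a step of a number 2 percentage points lower from compound 2 to compound 3 (within the scatter).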

Compound 3, percent growth inhibition at one concentration: 33%
Beside the measured number, compound 3's estimate is 13 percentage points below it; the measured number falls inside the stated range.
By their numbers in this assay, from the lowest: compounds 1 and 2 (each within the scatter of the next); then compound 3.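

In this assay, a step of a number 11 percentage points higher from compound 2 to compound 3 (beyond the scatter) shows that growth inhibition responds to the group on the aromatic carbon para to a large group. Compounds 1 and 2 differ in more than one place, so they could not show this. The data offer no explanation for the step.

On these data alone, whether an amine or a carboxylic acid at this position would raise or lower growth inhibition remains open. So does whether cyano in place of nitro would give a similar step if another part of compound 3 were changed.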